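Bromo to Trifluoromethoxy: Expected Effect on Cell Growth Inhibition

A few compounds are considered here, and "the series" means these few. Any claim that something is new, unique, unknown or untested is made for them only; others in the source may bear on it.

Of the compounds shown here, two have so far been tested in a functional assay on SGC-7901 cells (Homo sapiens) for antiproliferative activity, read by MTT assay, with a stated time of 72 h; on this read-out lower numbers stand for stronger inhibition and higher numbers for weaker inhibition. Compound 1, `COc1ccc(Oc2c(/C=N\OCc3c(Cl)c(-c4ccc(F)cc4)nn3C)c(C)nn2C)cc1`, gives 2840 nM. Compound 2, `Cc1nn(C)c(Oc2ccc(Br)cc2)c1/C=N\OCc1c(Cl)c(-c2ccc(Cl)cc2)nn1C`, gives 5960 nM, the higher of the two numbers, so within this small set it is the weaker inhibitor of cell growth. Compound 3, `Cc1nn(C)c(Oc2ccc(OC(F)(F)F)cc2)c1/C=N\OCc1c(Cl)c(-c2ccc(Cl)cc2)nn1C`, has not been measured yet. It differs from compound 2 in a single place: trifluoromethoxy in place of bromo on an aromatic carbon. Within the data shown here, no measured pair shows this exact change, so the size of its effect is uncertain. Because compound 2 sits at 5960 nM, the estimate for compound 3 is kept close to that value, with a 1.2-fold lower number from compound 2 to compound 3 (0.08 log units; within the scatter) expected to stay within the usual scatter, in either direction. On that basis compound 3 is expected to give about 5000 nM in this assay, with a plausible range from 2000 nM to 12000 nM.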

Compound 3, half-maximal inhibitory concentration: 3220 nM
Estimate against measurement, compound 3: 1.6-fold (0.19 log units) above; the range from low to high includes it.
By their numbers in this assay, from the lowest: compounds 1, 3 and 2 (each within the scatter of the next, the first and the last beyond it).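

Among these compounds, this is the first direct reading of a single change at this position of the phenoxy ring. In this assay, trifluoromethoxy in place of bromo, on an aromatic carbon para to a large group, gives a 1.9-fold lower number from compound 2 to compound 3 (0.27 log units; within the scatter), so the two compounds cannot be told apart here. At this place, then, a group of 5 heavy atoms that carries a hydrogen-bond acceptor can stand where a single bromine atom stood without a difference that repeated measurements could separate, and no measured property of these groups is available to explain the result.

Both groups shown in this comparison lack a charge and a hydrogen-bond donor. Going by these compounds, how an amine, a carboxylic acid or a longer chain such as butoxy would behave at this position remains open.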